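Swapping hydroxy for methylsulfonyl on the shared core

The source may hold more compounds than are shown below. What is called first, only, known or untested is meant among the compounds shown, and "the series" means these compounds.

- compound 1 `N#Cc1ccc(-c2cncc(-c3cc4ccc(O)cc4[nH]3)c2)cc1` gives 25000 nM
- compound 2 `Oc1ccc(-c2cncc(-c3cc4ccc(O)cc4[nH]3)n2)cc1` gives 4000 nM

Both numbers come from a functional assay on NCI60 cells (Homo sapiens) for cytotoxicity, with a stated time of 48 h (on this read-out lower numbers stand for stronger inhibition and higher numbers for weaker inhibition), and they differ by more than the usual scatter. Compound 2 holds the lower number of the pair, so it is the stronger inhibitor of these two. Compound 3 `CS(=O)(=O)c1ccc(-c2cncc(-c3cc4ccc(O)cc4[nH]3)n2)cc1` has not been measured yet. It differs from compound 2 by carrying methylsulfonyl in place of hydroxy on an aromatic carbon para to a large group. Among the compounds with values here, no measured pair shows this change, so the estimate is wide. The expected 2.5-fold higher number from compound 2 to compound 3 (0.40 log units; beyond the scatter) is a modest rise beyond the scatter, meaning weaker inhibition. Compound 3 is expected near 10000 nM with an estimated range from 3000 nM to 35000 nM in this assay once tested.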

Compound 3, half-maximal inhibitory concentration: 20000 nM
Estimate against measurement, compound 3: 2.0-fold (0.30 log units) below; the range from low to high includes it.
By their numbers in this assay, from the lowest: compound 2; then compounds 3 and 1 (each within the scatter of the next).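

Within the data shown here, this is the first direct reading at this position. In this assay, methylsulfonyl in place of hydroxy on an aromatic carbon gives a 5.0-fold higher number from compound 2 to compound 3 (0.70 log units; beyond the scatter), so this one change weakens inhibition by more than the usual scatter. The position therefore responds to what sits there, and of these two groups hydroxy gives the stronger inhibition. Nothing measured here explains the loss. Still open, from the compounds shown here alone, is how an amine, a methoxy group or a carboxylic acid on this carbon would compare with hydroxy and methylsulfonyl.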